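The source may report more compounds than this note shows. Statements on the series, on what has been measured and on what is new or still open speak of the compounds shown alone.

Compound 1 `CC1=CC[C@@H]([C@@](C)(O)CCCC(C)(C)NC(=S)NN)CC1` carries a thiosemicarbazide end group on its shared core, and compound 2 `CC1=CC[C@@H]([C@@](C)(O)CCCC(C)(C)NC(=S)N/N=C\c2cccc([N+](=O)[O-])c2)CC1` carries the same core with the hydrazine nitrogen condensed to a nitro-substituted benzaldehyde. In a functional assay on NCI-H460 cells (Homo sapiens) for cytotoxicity, read by sulforhodamine B assay (on this read-out higher numbers stand for weaker inhibition of growth and lower numbers for stronger inhibition of growth), compound 1 gives 84000 nM, while compound 2 gives 68600 nM; these two numbers lie within the usual scatter of each other, so on the numbers shown compound 1 cannot be told apart from compound 2. Compound 3 `CC1=CC[C@@H]([C@@](C)(O)CCCC(C)(C)NC(=S)N/N=C\c2ccccc2Cl)CC1` has not yet been measured. It differs from compound 1 by a group of 9 heavy atoms (7 carbon, 1 nitrogen, 1 chlorine; one six-membered aromatic ring of carbon only) in place of one nitrogen atom, on an amide-type nitrogen. Among the measured compounds shown here, since the only comparison at hand, that between compound 1 and compound 2, shows no shift beyond the scatter for a related aryl group placed on this nitrogen, the expectation is that the step from compound 1 to compound 3 in this assay will likewise be small, with a 1.4-fold lower number from compound 1 to compound 3 (0.15 log units; within the scatter) not clearly beyond the scatter in either direction. On that basis compound 3 is estimated at 60000 nM, expected to fall between 25000 nM and 150000 nM.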

Compound 3, concentration for total growth inhibition: > 100000 nM
Compound 3: only a limit was reported; the forecaster's own chance of this, stated with the estimate: 10%; at least 1.6-fold (0.22 log units) between middle value and limit.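

In this assay, the entry for compound 3 is a limit of the test and not a number: the limit of > 100000 nM in this assay, at which 1 of the 3 values shown sits. The steps to it can therefore be read only as floors, an at least 1.1-fold higher number from compound 1 to compound 3 (0.07 log units; that floor lies within the scatter) and an at least 1.4-fold higher number from compound 2 to compound 3 (0.16 log units; that floor lies within the scatter), and the true gaps may be larger or may be no more than ordinary scatter. What this adds is a second aryl group on the amide-type nitrogen: neither the 3-nitrophenyl group of compound 2 nor the 2-chlorophenyl group of compound 3 gives a number that stands clearly below that of compound 1, so the shown changes at this position bring no clear gain in growth inhibition.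

The compounds shown leave open how far compound 3 really lies from compound 1 and compound 2, and so whether exchanging 3-nitrophenyl for 2-chlorophenyl changes anything in this test. They also leave open what an unsubstituted phenyl ring, a small alkyl group such as methyl, or an aryl ring bearing a carboxylic acid would do at the same place on the shared core.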